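The compounds below may be only part of what the source reports. "The series", "measured", "known", "first", "only" and "open" are said of these compounds alone.

Of the compounds shown here, three have been measured in an assay on isolated protein for inhibition of C-C chemokine receptor type 4 (Homo sapiens); a higher number here means a weaker inhibitor, a lower number a stronger inhibitor. Compound 1, `CCN(CC)CCCC(C)Nc1nc(C(=O)Nc2ccccc2)nc2ccccc12`, gives only a limit: in this assay compound 1 reads > 10000 nM, which is the edge of what the measurement can report rather than a number. Only compound 1 sits at the limit of > 10000 nM in this assay, at which 1 of the 3 values shown sits. Compound 2, `CCN(CC)CCCC(C)Nc1ccnc(OCc2ccc(Cl)cc2Cl)n1`, gives 2800 nM in this assay. Compound 3, `CCN(CC)CCCNc1nccc(OCc2ccc(Cl)cc2Cl)n1`, gives 8000 nM in this assay, the highest of the two numbers shown; compound 2 sits lower, and the gap between compound 2 and compound 3 lies beyond the usual scatter.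

The next compound, compound 4, `CCN(CC)CCNc1nccc(OCc2ccc(Cl)cc2Cl)n1`, has not yet been measured in this assay. It differs from compound 3 in one place: diethylamino in place of (diethylamino)methyl on a saturated chain carbon, two bonds along the chain from a nitrogen on an aromatic ring. The chain that carries the diethylamino group is thus shorter.

Among the compounds with values here, no pair of measured compounds shows this kind of step, so the expectation rests on compound 3 alone. A shorter chain is expected to move the number only modestly, with a slight lean toward a weaker inhibitor, and the expected step is a 1.5-fold higher number from compound 3 to compound 4 (0.18 log units; within the scatter). Compound 4 is therefore expected to give about 12000 nM in this assay, within a range from 3000 nM to 40000 nM, and it may well come back as a limit only.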

Compound 4, half-maximal inhibitory concentration: 9000 nM
For compound 4 the middle estimate is 1.3-fold (0.12 log units) above the measured one, within the range that was stated.
By their numbers in this assay, from the lowest: compound 2; then compounds 3 and 4 (each within the scatter of the next). At a limit, above all of these: compound 1.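

Shortening the chain that carries the diethylamino group, from 3-(diethylamino)propyl to 2-(diethylamino)ethyl, gives the first step that can be read at this position, and in this assay it is a 1.1-fold higher number from compound 3 to compound 4 (0.05 log units; within the scatter). Within the scatter, the two compounds cannot be told apart, so across these two chain lengths the change leaves no detectable mark on the result. Compound 4 also still gives a number that can be read, and compound 1 alone remains at a limit: the limit of > 10000 nM in this assay, at which 1 of the 4 values shown sits.

Still open, as far as these compounds go, is whether a longer chain, such as 4-(diethylamino)butyl, or a different amine at the end of the chain, such as dimethylamino or piperidine, would move the number beyond the scatter. Compound 2 gives 2800 nM, but it differs from compound 3 in more than one place, so these compounds cannot show which of its features matter, including the methyl branch on its chain.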